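Shrinking the Saturated Ring on Compound 3

The source may hold more compounds than are shown below. What is called first, only, known or untested is meant among the compounds shown, and "the series" means these compounds.

Three compounds have numbers in a functional assay on cells for positive allosteric modulation of metabotropic glutamate receptor 2 (Homo sapiens), read by fluorescence and calcium flux, with a stated time of 30 min; on this read-out higher numbers stand for an effect only at larger amounts of compound and lower numbers for an effect already at smaller amounts. Compound 1 `Clc1ccc(-c2ccc(Cn3nnc4ccccc43)cc2)c(Cl)c1` gives 79 nM, and compound 2 `Clc1ccc(-c2ccc(Cn3nnc4ccccc43)cn2)cc1` gives 70 nM. Compound 3 `Brc1cccc2c1nnn2CC1CCCC1` stands lowest with 30 nM; its gaps to compound 2 and to compound 1 lie beyond the scatter, so of these three it acts at the smallest amount. Compound 4 `Brc1cccc2c1nnn2CC1CCC1` has not been measured. It differs from compound 3 in one place: cyclobutyl in place of cyclopentyl on a saturated chain carbon bound to an aromatic nitrogen. For the measured compounds named here, no measured pair shows what this change does here, so the expectation rests on compound 3 alone. The step of a 1.5-fold higher number from compound 3 to compound 4 (0.18 log units; within the scatter) is expected to be small, if beyond the scatter at all, and more likely toward a higher number. Compound 4 is estimated at 45 nM, within 15 nM to 150 nM.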

Compound 4, half-maximal effective concentration: 20 nM
The estimate for compound 4 lay 2.3-fold (0.35 log units) above the measured number; the measured number falls inside the stated range.
By their numbers in this assay, from the lowest: compounds 4 and 3 (each within the scatter of the next); then compounds 2 and 1 (each within the scatter of the next).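

For the compounds shown here, this is the first pair at this position, and the step (a 1.5-fold lower number from compound 3 to compound 4 (0.18 log units; within the scatter)) shows that cyclobutyl and cyclopentyl on a saturated chain carbon bound to an aromatic nitrogen cannot be told apart here. In this pair, the ring can therefore lose a carbon with no change beyond the scatter. Nothing at hand explains this result.

From the compounds shown here alone, whether cyclopropyl, cyclohexyl or an open chain such as isobutyl would fit this position equally well remains open. So does the effect of an amine or a carboxylic acid on the ring.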